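This account rests on a few compounds, and the source may have more. Where it says the series, first, only, none or still open, it means among the compounds named here.

Compound 1 `O=C(O)CSC(CC(=O)c1ccccc1)C(=O)O`: 15000 nM
Compound 2 `CCc1ccc(C(=O)CC(SCC(=O)O)C(=O)O)cc1`: 4790 nM
Compound 3 `CCCCCCCCCCCCc1ccc(C(=O)CC(SCC(=O)O)C(=O)O)cc1`: 1710 nM

All three compounds were measured in a functional assay on HeLa cells (Homo sapiens) for inhibition; on this read-out lower numbers stand for stronger inhibition and higher numbers for weaker inhibition. Compound 2, at 4790 nM, holds the middle place: compound 1 has the highest number of the three, compound 3 the lowest, and both gaps lie beyond the scatter.

The unmeasured compound 4 `O=C(O)CSC(CC(=O)c1ccc(F)cc1)C(=O)O` changes one group of compound 2: fluoro in place of ethyl on an aromatic carbon. This is fluoro in place of ethyl on an aromatic carbon, para to a large group.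

Within the data shown here, two measured steps bear on this change. Ethyl in place of hydrogen on an aromatic carbon gave a 3.1-fold lower number from compound 1 to compound 2 (0.50 log units; beyond the scatter), and the decyl change gave a 2.8-fold lower number from compound 2 to compound 3 (0.45 log units; beyond the scatter). Among the measured compounds shown here, both steps are modest, and in this small set each added stretch of chain went with a lower number, with no compound going against that. Compound 4 loses the ethyl group, so part of the first step may be given back. For the measured compounds named here, no measured compound carries fluoro, so the data cannot show how much. The expected change is modest and towards a higher number, estimated as a 2.1-fold higher number from compound 2 to compound 4 (0.32 log units; beyond the scatter). For compound 4 the estimated value in this assay is 10000 nM, with an expected range of 4000 nM to 25000 nM.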

Compound 4, half-maximal inhibitory concentration: 20700 nM
Estimate against measurement, compound 4: 2.1-fold (0.32 log units) below; low and high end bracket the measured number.
By their numbers in this assay, from the lowest: compound 3; then compound 2; then compounds 1 and 4 (each within the scatter of the next).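

In this assay, fluoro in place of ethyl on this aromatic carbon gives a 4.3-fold higher number from compound 2 to compound 4 (0.64 log units; beyond the scatter) and so removes the gain that compound 2 held over compound 1. Fluoro in place of hydrogen on the same carbon gives a 1.4-fold higher number from compound 1 to compound 4 (0.14 log units; within the scatter) and stays within the scatter, so on this read-out fluoro cannot be told apart from hydrogen at this position. Among these compounds, a small atom here does not lower the number the way the ethyl group does, and nothing measured here explains the difference.

Still open, as far as these compounds go, is whether a group without a carbon chain, such as a methoxy group or an amine, can lower the number at this position, and whether a single methyl group is already enough to do so. Also open is whether fluoro on another carbon of the six-membered aromatic ring would again match hydrogen, as only this one place on the ring is covered by the compounds shown.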